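The source may hold more compounds than are shown below. What is called first, only, known or untested is meant among the compounds shown, and "the series" means these compounds.

Measured in a functional assay (on this read-out lower numbers stand for stronger inhibition and higher numbers for weaker inhibition), so far:
- compound 1 `O=C(c1cc(/C=C/c2ccc(O)cc2)cc(C(=O)c2cc(O)c(O)c(O)c2)c1)c1cc(O)c(O)c(O)c1` gives 17.5 ug/mL
- compound 2 `O=C(/C=C/c1ccc(O)c(O)c1)c1cc(O)cc(/C=C/c2ccc(O)cc2)c1` gives 9.2 ug/mL

Among the compounds with values here, compound 2 stands within the usual scatter of compound 1, the only other measured compound, so the two cannot be told apart. Compound 3 `O=C(/C=C/c1cc(O)c(O)c(O)c1)c1cc(O)cc(/C=C/c2ccc(O)cc2)c1` departs from compound 2 by hydroxy in place of hydrogen on an aromatic carbon as hydroxy takes the place of hydrogen on an aromatic carbon, turning 3,4-dihydroxyphenyl into 3,4,5-trihydroxyphenyl. Within the data shown here, no measured pair shows this change, so no move beyond the scatter is expected in this assay and only a slight lean toward lower numbers. The estimated 1.2-fold lower number from compound 2 to compound 3 (0.09 log units; within the scatter) therefore stays small. For compound 3 the expected value is 7.5 ug/mL within an estimated range of 3.5 ug/mL to 16 ug/mL overall.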

Compound 3, half-maximal inhibitory concentration: 10 ug/mL
Estimate against measurement, compound 3: 1.3-fold (0.12 log units) below, and the stated range covers the measured number.
By their numbers in this assay, from the lowest: compounds 2, 3 and 1 (each within the scatter of the next).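

In this assay, hydroxy in place of hydrogen on an aromatic carbon, turning 3,4-dihydroxyphenyl into 3,4,5-trihydroxyphenyl, gives a 1.1-fold higher number from compound 2 to compound 3 (0.04 log units; within the scatter) and so cannot be told apart from no change. Within the data shown here, this is the first pair differing in one place, and it shows that this position, ortho to a hydroxy group, accepts the added hydroxy without a difference beyond the scatter. No evidence at hand bears on this result. Still open, from the compounds shown here alone, is how a methoxy group or an amine at this position would read in this assay, and whether a carboxylic acid there would move the number beyond the scatter.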